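Aryl ring substituents on the shared core in writhing inhibition

The compounds below may be only part of what the source reports. "The series", "measured", "known", "first", "only" and "open" are said of these compounds alone.

The shared core of compound 1 `O=C1N/C(=N/c2ccc(F)cc2)S/C1=C\c1ccccn1` carries an aryl group on the double-bonded nitrogen. In a functional assay on the whole organism (strain Swiss albino) for inhibition, with Mus musculus as the target, in the writhing test, with stated times of 30 min and 15 min, at a dose of 50 mg/kg by the oral route (a higher number here means more inhibition at the dose given (going by the name of the read-out), a lower number less inhibition), compound 1 gives 43.2%. Compound 2 `O=C1N/C(=N/c2ccccc2Cl)S/C1=C\c1ccccn1` differs by 2-chlorophenyl in place of 4-fluorophenyl on that nitrogen, and in this assay compound 2 gives 36.2%, the lowest of the two numbers measured; the step of a number 7 percentage points lower from compound 1 to compound 2 (within the scatter) is within the scatter, so the two values are not distinguished. Compound 3 `Cc1ccccc1/N=C1/NC(=O)/C(=C/c2ccccn2)S1` is not yet measured; it differs from compound 2 by methyl in place of chloro on an aromatic carbon, read one bond further out as 2-chlorophenyl to 2-methylphenyl. For the measured compounds named here, no measured step covers this exact exchange; the only step in hand, from compound 1 to compound 2, changed the aryl group and stayed within the scatter. The step of a number 1.8 percentage points higher from compound 2 to compound 3 (within the scatter) is therefore expected to stay within the scatter as well. For compound 3 in this assay a value of 38% is estimated, within a range of 26% to 50%.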

Compound 3, a percentage reported as inhibition, in the whole organism at one dose (the size of the read-out at that dose, not a potency): 43.6%
Estimate against measurement, compound 3: 5.6 percentage points below, and the stated range covers the measured number.
By their numbers in this assay, from the lowest: compounds 2, 1 and 3 (each within the scatter of the next).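

With methyl in place of chloro on an aromatic carbon, ortho to a large group, this assay gives a number 7.4 percentage points higher from compound 2 to compound 3 (within the scatter), so this first direct exchange at that place does not separate the two groups. With 2-methylphenyl in place of 4-fluorophenyl on the double-bonded nitrogen, the same read-out gives a number 0.4 percentage points higher from compound 1 to compound 3 (within the scatter), and the three aryl groups now shown remain undistinguished at this single dose. No measurement bearing on a cause of these values is available.

The aryl groups shown carry only chloro, fluoro or methyl, so it remains open whether an amine, a carboxylic acid or a longer chain on that ring would give a value beyond the scatter of these three. Also open, from the compounds shown here alone, is whether the three compounds would separate at another dose.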